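A few compounds are considered here, and "the series" means these few. Any claim that something is new, unique, unknown or untested is made for them only; others in the source may bear on it.

Of the compounds shown here, three have numbers so far in a physicochemical assay for pharmacokinetics, read by HPLC, at pH 9.0; on this read-out higher numbers stand for a longer-lived compound and lower numbers for a shorter-lived compound. Compound 1 (`CCCCCCNC(=O)Oc1cccc(-c2ccccc2)c1`) gives 1.14 h, the top number of the three. Compound 3 (`O=C(NCc1cccc2ccccc12)Oc1cccc(-c2ccccc2)c1`) gives 0.645 h, which lies within the usual scatter of compound 1. Compound 2 (`NC(=O)c1cccc(-c2cccc(OC(=O)NCCCCc3ccccc3)c2)c1`) gives 0.505 h, and its gap to compound 1 goes beyond that scatter.

Compound 4 (`O=C(NC1CCCC1)Oc1cccc(-c2ccccc2)c1`) has not been measured yet. It carries cyclopentyl in place of hexyl on an amide-type nitrogen. Going by the values given here, no two measured compounds differ in one place only, so no direct step is available as a guide. The nearest hint is compound 3, which has a different group on that nitrogen and still, at 0.645 h, stays within the scatter of compound 1. In this assay the expected step of a 1.3-fold higher number from compound 1 to compound 4 (0.12 log units; within the scatter) is therefore small, a slight and tentative rise that does not go beyond the scatter. For compound 4 the estimate is 1.5 h, with an expected range from 0.7 h to 3.2 h.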

Compound 4, half-life: 0.752 h
For compound 4 the middle estimate is 2.0-fold (0.30 log units) above the measured one; the range from low to high includes it.
By their numbers in this assay, from the lowest: compounds 2, 3, 4 and 1 (each within the scatter of the next, the first and the last beyond it).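

Going by these compounds alone, this is the first direct step at this position: on an amide-type nitrogen, with the rest of the molecule unchanged, cyclopentyl in place of hexyl gives a difference in this assay (a 1.5-fold lower number from compound 1 to compound 4 (0.18 log units; within the scatter)) that cannot be told apart from repeat scatter. Closing the open chain into a five-membered non-aromatic ring of carbon, with one heavy atom fewer, therefore leaves no clear mark on the half-life in this one pair. Nothing measured here explains why the two compounds read alike.

As far as these compounds go, whether any group on this nitrogen can shift the half-life beyond the scatter stays open: a single pair says nothing about a much shorter chain such as ethyl, a longer chain, or a chain ending in an amine or a carboxylic acid. Also open, from the compounds shown here alone, is whether the same swap would give a similar step on a different core.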